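Furan-2-yl for phenyl in a 2,4,6-triaryl series

The source may hold more compounds than are shown below. What is called first, only, known or untested is meant among the compounds shown, and "the series" means these compounds.

Of the compounds shown here, three of the shared core have been measured in a functional assay on DU-145 cells (Homo sapiens) for cytotoxicity, read by CCK-8 assay and cell counting, with a stated time of 2 days; a higher number here means a weaker inhibitor, a lower number a stronger inhibitor. Compound 1 `Oc1ccc(-c2cc(-c3ccc(Cl)cc3)nc(-c3cccnc3)c2)cc1` gives 22800 nM. Compound 2 `Oc1cccc(-c2cc(-c3ccc(Cl)cc3)nc(-c3ccco3)c2)c1` gives 11400 nM. Compound 3 `Oc1ccc(-c2cc(-c3ccccc3)nc(-c3ccc(Cl)cc3)c2)cc1` gives 7270 nM, the lowest of the three numbers; the nearest is compound 2, within the scatter, and the furthest is compound 1, beyond it. Among the compounds with values here, the only single-point step measured so far is a 3.1-fold lower number from compound 1 to compound 3 (0.50 log units; beyond the scatter), a modest move towards a lower number when a six-membered aromatic ring with one nitrogen gives way to phenyl at that position.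

Compound 4 `Oc1ccc(-c2cc(-c3ccc(Cl)cc3)nc(-c3ccco3)c2)cc1` is not yet measured. The change from compound 3 is furan-2-yl in place of phenyl on an aromatic carbon. Within the data shown here, this reverses the sense of the one measured step: a heteroaryl again takes the place of phenyl on the carbon next to the ring nitrogen, although the ring entering is five-membered, not the pyridin-3-yl that left in compound 1. Compound 2 already carries furan-2-yl at this position, with the hydroxy group elsewhere, and its value in this assay stands within the scatter of compound 3.

On this basis the number for compound 4 is expected to rise somewhat, a 1.7-fold higher number from compound 3 to compound 4 (0.22 log units; within the scatter), a step that may not clear the scatter. The estimate for compound 4 is 12000 nM, with a range from 4000 nM to 35000 nM.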

Compound 4, half-maximal inhibitory concentration: 7280 nM
Compound 4: middle estimate off by 1.6-fold (0.22 log units), on the high side, within the range that was stated.
By their numbers in this assay, from the lowest: compounds 3, 4, 2 and 1 (each within the scatter of the next, the first and the last beyond it).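

In this assay the aromatic carbon next to the ring nitrogen shows no separation between phenyl and furan-2-yl, with a 1.0-fold higher number from compound 3 to compound 4 (0.00 log units; within the scatter), so the smaller five-membered ring with its oxygen leaves the number where the six-membered carbon ring had it. Pyridin-3-yl now stands apart from both groups, since a 3.1-fold lower number from compound 1 to compound 3 (0.50 log units; beyond the scatter) and a 3.1-fold lower number from compound 1 to compound 4 (0.50 log units; beyond the scatter) are steps of the same size, and with only three groups at this position that holds for these compounds alone. Within the data shown here, with furan-2-yl held in place, the first reading on the hydroxy group gives a 1.6-fold lower number from compound 2 to compound 4 (0.19 log units; within the scatter), so 4-hydroxyphenyl and 3-hydroxyphenyl cannot be told apart here.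

Nothing shown accounts for why pyridin-3-yl differs from phenyl and furan-2-yl at this position. Still open, on these data alone, is whether a saturated amine such as morpholine or a carboxylic acid on this carbon would move the number beyond the scatter, and whether a methoxy group in place of the hydroxy group would change it.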